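The source may report more compounds than this note shows. Statements on the series, on what has been measured and on what is new or still open speak of the compounds shown alone.

Measured so far in an assay on CHO cells for displacement of a labelled ligand from Substance-P receptor (Homo sapiens), in the presence of a further agent that is not named here; on this read-out lower numbers stand for stronger inhibition and higher numbers for weaker inhibition:
- Compound 1 `C[C@@H](O[C@H]1CN2C(=O)C=C(c3ccncc3)CC2[C@@H]1c1ccc(F)cc1)c1cc(C(F)(F)F)cc(C(F)(F)F)c1` gives 8.1 nM.
- Compound 2 `C[C@@H](O[C@H]1CN2C(=O)C=C(c3cc[n+]([O-])cc3)CC2[C@@H]1c1ccc(F)cc1)c1cc(C(F)(F)F)cc(C(F)(F)F)c1` gives 2.1 nM.
- Compound 3 `COc1cc(C2=CC(=O)N3C[C@H](O[C@H](C)c4cc(C(F)(F)F)cc(C(F)(F)F)c4)[C@@H](c4ccc(F)cc4)C3C2)ccn1` gives 44 nM.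

Compound 1 stands second highest of the three numbers. Its nearest neighbour is compound 2, reached by a 3.9-fold lower number from compound 1 to compound 2 (0.59 log units; beyond the scatter); the furthest is compound 3, reached by a 5.4-fold higher number from compound 1 to compound 3 (0.73 log units; beyond the scatter). Both steps lie beyond the scatter, so on this small set the group on the double-bonded ring carbon of the shared core clearly matters, in both directions.

Compound 4 `C[C@@H](O[C@H]1CN2C(=O)C=C(C3=CCC(O)CC3)CC2[C@@H]1c1ccc(F)cc1)c1cc(C(F)(F)F)cc(C(F)(F)F)c1` is the next analogue. Relative to compound 1 the change is 4-hydroxycyclohex-1-en-1-yl in place of pyridin-4-yl on a double-bonded ring carbon. Among the compounds with values here, no measured step bears on it directly: the two measured steps keep the pyridin-4-yl and only add to it, whereas here the aromatic ring leaves altogether and a non-aromatic ring with a hydroxyl enters. The step from compound 1 to compound 2 shows that adding an oxygen to that group can lower the number, the step from compound 1 to compound 3 that adding a methoxy raises it; the range between them is wide. With the aromatic ring and its single hydrogen-bond acceptor gone, a modest rise in the number is expected rather than a fall, with a 2.2-fold higher number from compound 1 to compound 4 (0.35 log units; beyond the scatter) as the estimated step. For compound 4 the expected value in this assay is 18 nM, estimated between 4 nM and 70 nM.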

Compound 4, half-maximal inhibitory concentration: 13 nM
For compound 4 the middle estimate is 1.4-fold (0.14 log units) above the measured one, within the range that was stated.
By their numbers in this assay, from the lowest: compound 2; then compounds 1 and 4 (each within the scatter of the next); then compound 3.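

On the double-bonded ring carbon, 4-hydroxycyclohex-1-en-1-yl takes the place of pyridin-4-yl in this assay with a 1.6-fold higher number from compound 1 to compound 4 (0.21 log units; within the scatter), so no difference can be read between the aromatic ring with its hetero atom and a non-aromatic ring of carbon only. The same group stands clear of both modified pyridine rings, with a 3.4-fold lower number from compound 3 to compound 4 (0.53 log units; beyond the scatter) against the 2-methoxypyridin-4-yl group and a 6.2-fold higher number from compound 2 to compound 4 (0.79 log units; beyond the scatter) against the group of compound 2, so in these four compounds neither a ring nitrogen nor an aromatic ring at this position is needed for a value in the range of compound 1, while the lowest number still belongs to compound 2. No measurement at hand accounts for any of these steps.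

Open, as far as these compounds go, is whether the hydroxyl of compound 4 contributes at all; a plain cyclohexenyl, or an amine or a carboxylic acid in its place on the same ring, would test that. Also open, from the compounds shown here alone, is whether the ring double bond of the group matters, which a saturated 4-hydroxycyclohexyl group would settle.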